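Cyano for chloro on the anilide ring of compound 2

The source may hold more compounds than are shown below. What is called first, only, known or untested is meant among the compounds shown, and "the series" means these compounds.

Compound 2, `Cc1ccsc1CN(C(=O)Nc1cccc(Cl)c1)n1cnnc1`, is the only one of the two measured compounds that returns a number in a functional assay on MCF7 cells (Homo sapiens) for cytotoxicity, read by MTT assay, with a stated time of 48 h (a higher number here means a weaker inhibitor, a lower number a stronger inhibitor), where compound 2 gives 31200 nM. Compound 1, `Cc1ccsc1CN(C(=O)Nc1ccccc1)n1cnnc1`, carries hydrogen where compound 2 carries chloro. In this assay compound 1 gives > 50000 nM, which is a limit of the assay and not a number (the limit of > 50000 nM in this assay, at which 1 of the 2 values shown sits). The step of an at least 1.6-fold lower number from compound 1 to compound 2 (0.20 log units; that floor lies within the scatter) is therefore known only as a floor, and that floor lies within the scatter. Compound 3, `Cc1ccsc1CN(C(=O)Nc1cccc(C#N)c1)n1cnnc1`, is the compound still to be measured: cyano in place of chloro on an aromatic carbon, the change sitting on an aromatic carbon of a six-membered aromatic ring of carbon only, meta to a large group. For the measured compounds named here, no measured step exchanges chloro for cyano; the one step that touches this position gives no more than a floor within the scatter, so the expectation is no step beyond the scatter in this assay in either direction. Compound 3 is accordingly estimated at 35000 nM, with a range from 12000 nM to 100000 nM. That estimate corresponds to an expected step of a 1.1-fold higher number from compound 2 to compound 3 (0.05 log units; within the scatter).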

Compound 3, half-maximal inhibitory concentration: > 50000 nM
Compound 3: a limit, no number (the forecaster's own chance of this, stated with the estimate: 35%); middle value at least 1.4-fold (0.15 log units) from the limit.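

The exchange of chloro for cyano at this position gives an at least 1.6-fold higher number from compound 2 to compound 3 (0.20 log units; that floor lies within the scatter). For the compounds shown here, compound 3 stands at a limit of the assay and not at a number, so compound 2, with chloro, remains the only one of the three compounds to return a number in this assay: the limit of > 50000 nM in this assay, at which 2 of the 3 values shown sit. The step between compound 1 and compound 3 cannot be read, as both values are limits.

The compounds shown therefore leave open whether chloro differs from cyano or hydrogen here by more than the scatter, since both readable steps at this position are floors that lie within it. On these data alone, it also remains open whether an amine, a methoxy group or a carboxylic acid on this aromatic carbon would give a number in this assay, and whether any such number would differ from that of compound 2 by more than the scatter.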